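A Thiazole Replaces the Pyridine on the Amine Arm

A few compounds are considered here, and "the series" means these few. Any claim that something is new, unique, unknown or untested is made for them only; others in the source may bear on it.

Compound 1 `C=C1CC[C@@H]2[C@](C)(CNCc3cccc(OC)c3)[C@H](O)CC[C@@]2(C)[C@@H]1/C=C/C1=CCOC1=O` gives 780 nM in a functional assay on BMMC cells (Mus musculus, strain C57BL/6) for inhibition, with stated times of 5 days and 48 h; on this read-out higher numbers stand for weaker inhibition and lower numbers for stronger inhibition.
Compound 2 `C=C1CC[C@@H]2[C@](C)(CNCc3ccc(Cl)cc3)[C@H](O)CC[C@@]2(C)[C@@H]1/C=C/C1=CCOC1=O` gives 420 nM in this assay.
Compound 3 `C=C1CC[C@@H]2[C@](C)(CNCc3ccncc3)[C@H](O)CC[C@@]2(C)[C@@H]1/C=C/C1=CCOC1=O` gives 2030 nM in this assay.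

Among the three measured compounds, compound 3 stands highest, and both of its steps from the other two lie beyond the scatter: a 2.6-fold higher number from compound 1 to compound 3 (0.42 log units; beyond the scatter) and a 4.8-fold higher number from compound 2 to compound 3 (0.68 log units; beyond the scatter). The two phenyl-bearing compounds sit close to each other, as a 1.9-fold lower number from compound 1 to compound 2 (0.27 log units; within the scatter) shows.

Compound 4 `C=C1CC[C@@H]2[C@](C)(CNCc3nccs3)[C@H](O)CC[C@@]2(C)[C@@H]1/C=C/C1=CCOC1=O` differs from compound 3 in one place: 1,3-thiazol-2-yl in place of pyridin-4-yl on a saturated chain carbon bound to an amine nitrogen. Within the data shown here, no measured step exchanges one heteroaromatic ring for another on this carbon, so the only guidance comes from the three steps above, which together show that changes of the ring at this position have moved the number by modest amounts at most. Among the measured compounds shown here, a move from pyridin-4-yl to 1,3-thiazol-2-yl is therefore expected to produce a step of similar size or smaller, and there is no measured step that points to a direction. On that basis compound 4 is expected to stay near compound 3, with an estimated step of a 1.2-fold lower number from compound 3 to compound 4 (0.08 log units; within the scatter). The estimate for compound 4 in this assay is 1700 nM, with a range from 650 nM to 4500 nM.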

Compound 4, half-maximal inhibitory concentration: 700 nM
Estimate against measurement, compound 4: 2.4-fold (0.39 log units) above; the range from low to high includes it.
By their numbers in this assay, from the lowest: compounds 2, 4 and 1 (each within the scatter of the next); then compound 3.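

In this assay, the step from pyridin-4-yl to 1,3-thiazol-2-yl on a saturated chain carbon bound to an amine nitrogen is the only exchange of one heteroaromatic ring for another among these compounds, and it gives a 2.9-fold lower number from compound 3 to compound 4 (0.46 log units; beyond the scatter). This shows that the number at this position depends on which heteroaromatic ring is present, so pyridin-4-yl cannot stand for heteroaromatic rings in general. The thiazole-bearing compound also falls in with the two phenyl-bearing compounds, with a 1.7-fold higher number from compound 2 to compound 4 (0.22 log units; within the scatter) and a 1.1-fold lower number from compound 1 to compound 4 (0.05 log units; within the scatter), which leaves compound 3 alone at the high end, with steps beyond the scatter to all three others. Nothing available explains why the two heteroaromatic rings differ.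

The compounds shown leave open whether a pyridin-2-yl or a 1,3-oxazol-2-yl ring on this carbon would read like compound 3 or like compounds 1, 2 and 4 in this assay. They also leave open whether any aromatic ring is needed here at all, a question that a cyclohexyl group on this carbon would address.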